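The source may report more compounds than this note shows. Statements on the series, on what has been measured and on what is new or still open speak of the compounds shown alone.

Compound 1 `CCC[N+](C)(C)CCCC(=O)[O-]` belongs to the same series as the rest. In an assay for inhibition of gamma-butyrobetaine dioxygenase (Homo sapiens), read by HPLC, with stated times of 15 min and 30 min (on this read-out lower numbers stand for stronger inhibition and higher numbers for weaker inhibition), compound 1 gives only a limit, > 1000000 nM, with no number behind it. Compound 2 `CN(CCC(=O)[O-])[N+](C)(C)C` is the one compound with a number: in this assay compound 2 gives 90 nM, which is the only number shown. The other value, that of compound 1, is a limit, as the limit of > 1000000 nM in this assay, at which 1 of the 2 values shown sits, records. Compound 3 `CCC[N+](C)(C)N(C)CCC(=O)[O-]` carries ethyl in place of hydrogen on a saturated chain carbon bound to an amine nitrogen. Among the measured compounds shown here, no step between measured compounds is known, so the direction rests on compound 1, whose value > 1000000 nM is a limit. The step from compound 2 to compound 3 is expected to weaken inhibition beyond the scatter, a 56-fold higher number from compound 2 to compound 3 (1.74 log units; beyond the scatter). Compound 3 is therefore estimated at 5000 nM, likely between 500 nM and 100000 nM.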

Compound 3, half-maximal inhibitory concentration: 3100 nM
Compound 3: middle estimate off by 1.6-fold (0.21 log units), on the high side; the measured number falls inside the stated range.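

In this assay, among the compounds shown here, the one measured step is large: methyl to propyl, on a saturated chain carbon bound to an amine nitrogen, gives a 34-fold higher number from compound 2 to compound 3 (1.54 log units; beyond the scatter). This position is therefore sensitive to chain length, yet compound 3 with its propyl group still gives a measured 3100 nM. Compound 1 also carries propyl and remains a limit: the limit of > 1000000 nM in this assay, at which 1 of the 3 values shown sits.

From the compounds shown here alone, whether an ethyl group falls between methyl and propyl stays open. So does the effect of a longer chain such as butyl or a branched one such as isopropyl.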